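Hydroxyphenyl placement scan on the shared core

The compounds below may be only part of what the source reports. "The series", "measured", "known", "first", "only" and "open" are said of these compounds alone.

Within the data shown here, compound 2 `Oc1ccccc1-c1cc(-c2ccccc2O)nc(-c2ccccc2O)c1` holds the lower of the two numbers so far in a functional assay on T47D cells (Homo sapiens) for cytotoxicity, read by CCK-8 assay, with a stated time of 4 days (on this read-out lower numbers stand for stronger inhibition and higher numbers for weaker inhibition), where compound 2 gives 2510 nM. Among the measured compounds shown here, its nearest neighbour, compound 1 `Oc1cccc(-c2cc(-c3ccccc3O)nc(-c3ccccc3O)c2)c1`, gives 3420 nM in this assay, and the only measured step, a 1.4-fold lower number from compound 1 to compound 2 (0.13 log units; within the scatter), lies within the scatter. Compound 3 `Oc1ccc(-c2cc(-c3ccccc3O)nc(-c3ccccc3O)c2)cc1` carries the change (4-hydroxyphenyl in place of 2-hydroxyphenyl on an aromatic carbon). That single step is the only one bearing on this move and it was small, so the expected shift in this assay is a 1.2-fold higher number from compound 2 to compound 3 (0.08 log units; within the scatter), nothing beyond the scatter. Compound 3 is therefore estimated at 3000 nM, within 1200 nM to 7500 nM.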

Compound 3, half-maximal inhibitory concentration: 18300 nM
Compound 3: the middle estimate sits 6.1-fold (0.79 log units) below what was measured; measured number outside the range, above it.
By their numbers in this assay, from the lowest: compounds 2 and 1 (each within the scatter of the next); then compound 3.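

At this place, opposite the ring nitrogen, the position of the hydroxyl on the phenyl group now matters in this assay, with a 7.3-fold higher number from compound 2 to compound 3 (0.86 log units; beyond the scatter) and a 5.4-fold higher number from compound 1 to compound 3 (0.73 log units; beyond the scatter). The earlier step between 2-hydroxyphenyl and 3-hydroxyphenyl stayed within the scatter, so among these three compounds only the 4-hydroxyphenyl group of compound 3 stands apart, although it matches the leaving group in every count. Nothing available accounts for this shift. Still open, as far as these compounds go, is whether a 4-aminophenyl or 4-methoxyphenyl group would track compound 3 here, and whether the two 2-hydroxyphenyl groups respond to the same change.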